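Pyrrolidin-1-yl to Diisopropylamino on Two Related Cores

A few compounds are considered here, and "the series" means these few. Any claim that something is new, unique, unknown or untested is made for them only; others in the source may bear on it.

Compound 1 `COc1ccc2occ(CSC(=S)N(C(C)C)C(C)C)c(=O)c2c1`: > 40000 nM, which is a limit of the assay rather than a number.
Compound 2 `Cc1ccc2c(=O)c(CSC(=S)N3CCCC3)coc2c1`: 41400 nM.
Compound 3 `COc1ccc2occ(CSC(=S)N3CCCC3)c(=O)c2c1`: 34100 nM.

All three were tested in a functional assay on MCF7 cells (Homo sapiens) for antiproliferative activity, read by MTT assay, with a stated time of 72 h; a lower number here means a stronger inhibitor, a higher number a weaker inhibitor. Compound 3 and compound 2 give numbers that sit within the scatter of each other, so nothing can be said about their order. Compound 1 differs from compound 3 in one place: diisopropylamino in place of pyrrolidin-1-yl on a thiocarbonyl carbon. The step it made is an at least 1.1-fold higher number from compound 3 to compound 1 (0.06 log units; that floor lies within the scatter), and its floor rests on (the limit of > 40000 nM in this assay, at which 1 of the 3 values shown sits), so the true size of that step is not pinned down.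

Compound 4 `Cc1ccc2c(=O)c(CSC(=S)N(C(C)C)C(C)C)coc2c1` has not yet been measured. It differs from compound 2 in the same way: diisopropylamino in place of pyrrolidin-1-yl on a thiocarbonyl carbon. The difference between the core of compound 2 and the core of compound 3 is not broken down here, so the two instances of the change sit on cores whose relation is not counted.

Against that background, the step from compound 2 to compound 4 is expected to be a 1.2-fold higher number from compound 2 to compound 4 (0.06 log units; within the scatter), because the same change gave an at least 1.1-fold higher number from compound 3 to compound 1 (0.06 log units; that floor lies within the scatter) and compound 2 already starts from 41400 nM. On this basis compound 4 is estimated at 48000 nM, between 30000 nM and 80000 nM, with a good chance that the assay will report only a limit.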

Compound 4, half-maximal inhibitory concentration: 6600 nM
The estimate for compound 4 lay 7.3-fold (0.86 log units) above the measured number; measured number below the stated range.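

In this assay, diisopropylamino in place of pyrrolidin-1-yl on a thiocarbonyl carbon gave a 6.3-fold lower number from compound 2 to compound 4 (0.80 log units; beyond the scatter), so on the core of compound 2 the change made a clear difference. Set beside its earlier instance on the core of compound 3, the change did not carry over with the same outcome, and its effect in this series therefore depends on the core it sits on: the same change on two cores in this assay, an at least 1.1-fold higher number (0.06 log units; that floor lies within the scatter) from compound 3 to compound 1 and a 6.3-fold lower number (0.80 log units; beyond the scatter) from compound 2 to compound 4, at least 7.3-fold (0.86 log units) apart, beyond the scatter of two such steps. The number for compound 1 is a limit of the assay and not a number that fixes the earlier step, so the true size of that step and of the gap stays open, and two instances neither explain what in the cores separates them nor give a rule for any further core: the limit of > 40000 nM in this assay, at which 1 of the 4 values shown sits.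

The compounds shown leave open whether other amines on the thiocarbonyl carbon, such as diethylamino or morpholin-4-yl, would follow compound 4 or compound 1 on these two cores. They also leave open whether the lower number seen with compound 4 would hold if chloro or a bare hydrogen stood in place of the methyl group of its core.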